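The source may report more compounds than this note shows. Statements on the series, on what has been measured and on what is new or still open speak of the compounds shown alone.

Among the compounds with values here, in a functional assay on SW-620 cells (Homo sapiens) for inhibition, read by MTT assay, with a stated time of 72 h (a higher number here means a weaker inhibitor, a lower number a stronger inhibitor), compound 1 (`COc1cc(NC(C)CCCNC(=O)Nc2ccc(F)cc2)c2ncccc2c1`) gives 25000 nM and compound 2 (`COc1cc(NC(C)CCCNC(=O)Nc2cccc(O)c2)c2ncccc2c1`) gives 27000 nM in the same test, which places compound 2 level with the only other measured compound. Within the data shown here, the one measured step, a 1.1-fold higher number from compound 1 to compound 2 (0.03 log units; within the scatter), puts 3-hydroxyphenyl in place of 4-fluorophenyl on an amide-type nitrogen. Compound 3 (`COc1cc(NC(C)CCCNC(=O)NNC(=O)Nc2cccc(F)c2)c2ncccc2c1`) departs from compound 2 at that same place through ((3-fluorophenyl)carbamoyl)amino in place of 3-hydroxyphenyl on an amide-type nitrogen and carries ((3-fluorophenyl)carbamoyl)amino there. Among the measured compounds shown here, no measured step adds a group of this kind, so the single step from compound 1 to compound 2 is only a weak guide. No shift beyond the scatter is therefore expected in this assay, though with wide uncertainty. The expected step is a 1.4-fold lower number from compound 2 to compound 3 (0.13 log units; within the scatter) and so remains small. Compound 3 is estimated at 20000 nM with an expected range of 6000 nM to 60000 nM in this test.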

Compound 3, half-maximal inhibitory concentration: 9500 nM
Compound 3: middle estimate off by 2.1-fold (0.32 log units), on the high side; measured number inside the range.
By their numbers in this assay, from the lowest: compound 3; then compounds 1 and 2 (each within the scatter of the next).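

In this assay, this position on the amide-type nitrogen proved able to move the number beyond the scatter: ((3-fluorophenyl)carbamoyl)amino gives a 2.8-fold lower number from compound 2 to compound 3 (0.45 log units; beyond the scatter), and against the 4-fluorophenyl group it gives a 2.6-fold lower number from compound 1 to compound 3 (0.42 log units; beyond the scatter). The earlier exchange of one substituted phenyl group for another had shown no such shift, whereas this change brings in a larger group that still carries a six-membered aromatic ring of carbon only. Nothing measured here explains the stronger inhibition by compound 3.

The compounds shown leave open whether the shift belongs to the added carbamoylamino stretch or to the 3-fluorophenyl ring at its end. They also leave open whether a longer chain at this place, or an amine or carboxylic acid on the ring in place of the fluorine, would keep the lower number.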